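The source may hold more compounds than are shown below. What is called first, only, known or untested is meant among the compounds shown, and "the series" means these compounds.

Measured compounds in an ADME assay on cells (Macrophage, Mus musculus) for cytotoxicity, read by resazurin assay, with a stated time of 3 days; on this read-out higher numbers stand for weaker inhibition and lower numbers for stronger inhibition:
- compound 1 `O=C(Nc1ccc(F)cc1)c1cc(Cl)ccc1O`: 17000 nM
- compound 2 `O=C(Nc1ccc(OC(F)(F)F)cc1)c1cc(Cl)ccc1O`: 7300 nM
- compound 3 `NC(=O)c1ccc(NC(=O)c2cc(Cl)ccc2O)cc1`: > 60000 nM

Among the numbers reported, compound 1 stands highest; its nearest neighbour is compound 2, with a 2.3-fold lower number from compound 1 to compound 2 (0.37 log units; beyond the scatter). For compound 3 the assay gives only a limit, (the limit of > 60000 nM in this assay, at which 1 of the 3 values shown sits), and no number. The step from compound 1 to compound 3 is an at least 3.5-fold higher number from compound 1 to compound 3 (0.54 log units; beyond the scatter), and from compound 2 to compound 3 it is an at least 8.2-fold higher number from compound 2 to compound 3 (0.91 log units; beyond the scatter).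

Compound 4 `O=C(Nc1ccc(F)c(F)c1)c1cc(Cl)ccc1O` differs from compound 1 by fluoro in place of hydrogen on an aromatic carbon. Within the data shown here, no measured step changes this position in the same way. The two steps that touch the same ring, compound 1 to compound 2 and compound 1 to compound 3, both exchange the fluoro group for a larger group, and both move the number beyond the scatter, in opposite directions. The addition of a single fluoro group is a smaller change than either, so the expected step from compound 1 to compound 4 is a 1.3-fold lower number from compound 1 to compound 4 (0.12 log units; within the scatter), within the scatter. Compound 4 is therefore estimated at 13000 nM, with a range from 5000 nM to 35000 nM.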

Compound 4, half-maximal inhibitory concentration: 7700 nM
Compound 4: middle estimate off by 1.7-fold (0.23 log units), on the high side; measured number inside the range.
By their numbers in this assay, from the lowest: compounds 2 and 4 (each within the scatter of the next); then compound 1. At a limit, above all of these: compound 3.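

In this assay, adding a fluoro group to a ring carbon that carried only hydrogen, with the original fluoro group kept, gives a 2.2-fold lower number from compound 1 to compound 4 (0.34 log units; beyond the scatter). Among these compounds, the earlier steps only exchanged the fluoro group itself, so this is the first sign that this neighbouring ring carbon also matters, and that a single added fluorine is enough to move the number beyond the scatter. Nothing measured here gives a cause for this step.

The compounds shown leave open whether a chloro group, an amine or a carboxylic acid on this same carbon would also lower the number. They also leave open whether the added fluoro group would have the same effect on a ring without the original fluoro group.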